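Dihydroxypropyl triazole replaces methylpiperazinyl chain on the core

This account rests on a few compounds, and the source may have more. Where it says the series, first, only, none or still open, it means among the compounds named here.

Measured compounds:
compound 1 `CN1CCN(CCCCCn2c3c(c4ccccc42)C(=O)c2c[n+]([O-])c4ccccc4c2C3=O)CC1` 1220 nM
compound 2 `CC1(C)OCC(Cn2cc(Cn3c4c(c5ccccc53)C(=O)c3c[n+]([O-])c5ccccc5c3C4=O)nn2)O1` 70 nM

In a functional assay on HCT-116 cells (Homo sapiens) for cytotoxicity, read by MTT assay, with a stated time of 72 h (a higher number here means a weaker inhibitor, a lower number a stronger inhibitor), compound 1 gives the highest of the two numbers; compound 2 gives a lower number, a gap beyond the scatter. Compound 3 `O=C1c2c[n+]([O-])c3ccccc3c2C(=O)c2c1c1ccccc1n2Cc1cn(CC(O)CO)nn1` differs from compound 1 in one place: 1-(2,3-dihydroxypropyl)-1H-1,2,3-triazol-4-yl in place of 4-(4-methylpiperazin-1-yl)butyl on a saturated chain carbon bound to an aromatic nitrogen. Among the measured compounds shown here, no measured pair isolates this change, so the step is expected, not known. Compound 2, which also carries a triazole, gives 70 nM, and a lower number is therefore expected for compound 3 in this assay, a step of an 11-fold lower number from compound 1 to compound 3 (1.04 log units; beyond the scatter) well beyond the scatter. Compound 3 is estimated at 110 nM, within 35 nM to 400 nM.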

Compound 3, half-maximal inhibitory concentration: 250 nM
Estimate against measurement, compound 3: 2.3-fold (0.36 log units) below; the range from low to high includes it.
By their numbers in this assay, from the lowest: compound 2; then compound 3; then compound 1.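

In this assay the step of a 4.9-fold lower number from compound 1 to compound 3 (0.69 log units; beyond the scatter) gives a measured size to placing 1-(2,3-dihydroxypropyl)-1H-1,2,3-triazol-4-yl in place of 4-(4-methylpiperazin-1-yl)butyl on a saturated chain carbon bound to an aromatic nitrogen. Opening the protected diol gives back part of the triazole's advantage: 1,2-dihydroxyethyl in place of 2,2-dimethyl-1,3-dioxolan-4-yl brings a 3.6-fold higher number from compound 2 to compound 3 (0.55 log units; beyond the scatter) in the same assay. No measurement at hand accounts for either step. Still open, as far as these compounds go, is whether the triazole or the diol carries the gain over the methylpiperazinyl chain, and how an amine or a carboxylic acid on the triazole would compare.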